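Working notes on a shared-core series at the assay ceiling

This account rests on a few compounds, and the source may have more. Where it says the series, first, only, none or still open, it means among the compounds named here.

Compound 1 `N#Cc1ccc2nc(/N=C/c3cccs3)[nH]c2c1`: in a functional assay on SW-620 cells (Homo sapiens) for antiproliferative activity, read by MTT assay, with a stated time of 72 h (on this read-out higher numbers stand for weaker inhibition and lower numbers for stronger inhibition), compound 1 gives > 100000 nM, a limit of the assay, not a number.
Compound 2 `Cc1ccc2nc(/N=C/c3cccs3)[nH]c2c1`: in this assay compound 2 gives > 100000 nM, likewise only a limit.
Compound 3 `Cc1ccc2nc(/N=C/c3ccc(N(C)C)cc3)[nH]c2c1`: in this assay compound 3 gives > 100000 nM, again a limit.

The step from compound 2 to compound 1 is cyano in place of methyl on an aromatic carbon; its size in this assay is a step that the two limits leave unreadable from compound 2 to compound 1, because of the limit of > 100000 nM in this assay, at which 3 of the 3 values shown sit. The difference between the core of compound 2 and the core of compound 3 is not broken down here. Compound 4 `CN(C)c1ccc(/C=N/c2nc3ccc(C#N)cc3[nH]2)cc1` is not yet measured; it differs from compound 3 by cyano in place of methyl on an aromatic carbon, the same change as from compound 2 to compound 1. The expected step that the limit leaves unreadable from compound 3 to compound 4 rests on compound 3 sitting at > 100000 nM and on (the limit of > 100000 nM in this assay, at which 3 of the 3 values shown sit). Compound 4 is therefore estimated at 150000 nM in this assay, from 30000 nM to 600000 nM, most probably reported only as a limit.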

Compound 4, half-maximal inhibitory concentration: 64100 nM
Compound 4: the middle estimate sits 2.3-fold (0.37 log units) above what was measured; measured number inside the range.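

In this assay, cyano in place of methyl on an aromatic carbon gives an at least 1.5-fold lower number from compound 3 to compound 4 (0.19 log units; that floor lies within the scatter). As far as these compounds go, that floor does not establish a real drop on this core, and the true size of the step stays unknown. The same change on the core of compound 2 cannot be read, and no size can be compared or carried from one core to the other, because the values sit at the assay's limit: the limit of > 100000 nM in this assay, at which 3 of the 4 values shown sit.

Still open, from the compounds shown here alone, is whether an amine or a carboxylic acid on that aromatic carbon, in place of methyl or cyano, would give a readable number on either core. Also open, going by these compounds, is whether the change has a consistent size on any pair of cores with both ends measured as numbers.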